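A second chloro on the chlorophenyl group of compound 3

The compounds below may be only part of what the source reports. "The series", "measured", "known", "first", "only" and "open" are said of these compounds alone.

Three amides built on a shared core have been measured. In an assay on brain for inhibition of Fatty-acid amide hydrolase 1 (Rattus norvegicus), read by scintillation counting, with a stated time of 10 min (a higher number here means a weaker inhibitor, a lower number a stronger inhibitor), compound 1 `CC(C)Cc1ccc(C(C)C(=O)NCc2ccccc2)cc1` gives 21000 nM, compound 2 `CC(C)Cc1ccc(C(C)C(=O)NCc2ccc(C(F)(F)F)cc2)cc1` gives 51000 nM, and compound 3 `CC(C)Cc1ccc(C(C)C(=O)N2CCN(c3cccc(Cl)c3)CC2)cc1` gives 1700 nM, the lowest of the three numbers and clear of both others beyond the scatter. For the measured compounds named here, the only single-point step measured, a 2.4-fold higher number from compound 1 to compound 2 (0.39 log units; beyond the scatter), places a group on a different ring from the one changed here. Compound 4 `CC(C)Cc1ccc(C(C)C(=O)N2CCN(c3ccc(Cl)c(Cl)c3)CC2)cc1` differs from compound 3 by chloro in place of hydrogen on an aromatic carbon, turning 3-chlorophenyl into 3,4-dichlorophenyl. Going by the values given here, no measured step bears on this change directly, and the one known step was modest. One therefore expects for compound 4 a step of a 1.1-fold lower number from compound 3 to compound 4 (0.05 log units; within the scatter), not beyond the scatter. The value expected for compound 4 in this assay is 1500 nM. The range expected for compound 4 runs from 500 nM to 5000 nM.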

Compound 4, half-maximal inhibitory concentration: 16000 nM
For compound 4 the middle estimate is 11-fold (1.03 log units) below the measured one; measured number above the stated range.
By their numbers in this assay, from the lowest: compound 3; then compounds 4 and 1 (each within the scatter of the next); then compound 2.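

The step of a 9.4-fold higher number from compound 3 to compound 4 (0.97 log units; beyond the scatter) in this assay shows that this aromatic carbon, ortho to a chloro group and para to a large group, is not indifferent to substitution: one added chloro clearly moves the number upward. The earlier step lay on a different ring and could not show this. Nothing given here accounts for the size of this step. From the compounds shown here alone, it remains open whether fluoro, methyl or methoxy at this carbon would give a comparable step. Going by these compounds, it also remains open whether chloro here would behave alike without the chloro group already present in compound 3.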